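Chain and amine changes on a shared core

This account rests on a few compounds, and the source may have more. Where it says the series, first, only, none or still open, it means among the compounds named here.

- In a functional assay on PC-3 cells (Homo sapiens) for antiproliferative activity, read by WST assay, with a stated time of 3 days (on this read-out higher numbers stand for weaker inhibition and lower numbers for stronger inhibition), compound 1 `CCN(CC)CCCCOc1c(-c2cc(OC)c(OC)c(OC)c2)oc2ccccc2c1=O` gives 13700 nM
- In this assay compound 2 `CCN(CC)CCCCCOc1c(-c2cc(OC)c(OC)c(OC)c2)oc2ccccc2c1=O` gives 6600 nM
- In this assay compound 3 `CCCCN(CCCC)CCCCCOc1c(-c2cc(OC)c(OC)c(OC)c2)oc2ccccc2c1=O` gives 6800 nM

On these numbers compound 3 is separated from neither of the other two. The steps are a 1.0-fold higher number from compound 2 to compound 3 (0.01 log units; within the scatter) and a 2.0-fold lower number from compound 1 to compound 3 (0.30 log units; within the scatter) and both stay inside the scatter.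

The next structure is compound 4 `CCCCCN(CCCCC)CCCOc1c(-c2cc(OC)c(OC)c(OC)c2)oc2ccccc2c1=O` with the same atoms joined differently. The change is dipentylamino in place of 2-(dibutylamino)ethyl on a saturated chain carbon, three bonds along the chain from an oxygen on an aromatic ring and amounts to dipentylamino in place of 2-(dibutylamino)ethyl on a saturated chain carbon, three bonds along the chain from an oxygen on an aromatic ring.

Within the data shown here, two measured steps bear on it, one for each part of the change. Lengthening the chain gave a 2.1-fold lower number from compound 1 to compound 2 (0.32 log units; beyond the scatter) and this modest single step, read in reverse, points to a somewhat higher number for a shorter chain. Exchanging the groups on the nitrogen gave a 1.0-fold higher number from compound 2 to compound 3 (0.01 log units; within the scatter) and so points in no direction. Among the measured compounds shown here, no measured compound has this shorter chain, and none has dipentylamino, so the expectation is loose. The expected step is a 1.3-fold higher number from compound 3 to compound 4 (0.12 log units; within the scatter) and it would probably stay within the scatter. Compound 4 is estimated at 9000 nM with 4000 nM to 20000 nM as its expected range.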

Compound 4, half-maximal inhibitory concentration: 5800 nM
Estimate against measurement, compound 4: 1.6-fold (0.19 log units) above; the measured number falls inside the stated range.
By their numbers in this assay, from the lowest: compounds 4, 2, 3 and 1 (each within the scatter of the next, the first and the last beyond it).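

Compound 4 holds the same 11 heavy atoms as compound 3, rearranged so that dipentylamino replaces 2-(dibutylamino)ethyl on a saturated chain carbon, and in this assay this gives a 1.2-fold lower number from compound 3 to compound 4 (0.07 log units; within the scatter) and, against the diethylamino compound, a 1.1-fold lower number from compound 2 to compound 4 (0.06 log units; within the scatter) as well, so neither step separates the compounds. The earlier single chain step had hinted that a shorter chain would cost activity, but with dipentylamino on the shorter chain the compound remains level with compounds 2 and 3, and only a 2.4-fold lower number from compound 1 to compound 4 (0.37 log units; beyond the scatter) reaches beyond the scatter, a modest step that also changes the chain and the amine together. The series therefore shows that a shorter chain does not by itself bring a compound back to the number of compound 1, at least when it carries this larger amine.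

Chain and amine change at once in every step to compound 4, so their separate contributions remain unresolved, and dipentylamino on a longer chain would be needed to divide them. Whether a ring amine such as piperidine or morpholine would behave like these open-chain amines also stays open, and nothing available gives a reason for any of these numbers.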